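The compounds below may be only part of what the source reports. "The series", "measured", "known", "first", "only" and "open" are said of these compounds alone.

Measured so far in an assay on isolated protein for binding affinity to Equilibrative nucleoside transporter 1 (Homo sapiens); a lower number here means a stronger inhibitor, a higher number a weaker inhibitor:
compound 1 `OC[C@H]1O[C@@H](n2cnc3c(SCC4CCCCC4)ncnc32)[C@H](O)[C@@H]1O` gives 1550 nM;
compound 2 `CCCCSc1nc(N)nc2c1ncn2[C@@H]1O[C@H](CO)[C@@H](O)[C@H]1O` gives 12000 nM;
compound 3 `Nc1nc(SCc2ccc(F)cc2)c2ncn([C@@H]3O[C@H](CO)[C@@H](O)[C@H]3O)c2n1` gives 1150 nM.

Compound 1 stands second highest of the three numbers; compound 3 lies within the scatter of it, while compound 2 sits beyond the scatter at a higher number.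

Compound 4 `OC[C@H]1O[C@@H](n2cnc3c(CSc4cccc(Br)c4)ncnc32)[C@H](O)[C@@H]1O` is not yet measured. It differs from compound 1 by ((3-bromophenyl)sulfanyl)methyl in place of (cyclohexylmethyl)sulfanyl on an aromatic carbon. Among the measured compounds shown here, the one step that bears on this is a 10-fold lower number from compound 2 to compound 3 (1.02 log units; beyond the scatter), where 4-fluorophenyl replaced propyl; here too a saturated carbon ring gives way to an aromatic one carrying a halogen, though the groups are joined differently, so the parallel is loose. A moderately lower number is therefore expected for compound 4: a 2.6-fold lower number from compound 1 to compound 4 (0.41 log units; beyond the scatter). Compound 4 is estimated at 600 nM, within 200 nM to 2500 nM.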

Compound 4, half-maximal inhibitory concentration: 363 nM
Compound 4: middle estimate off by 1.7-fold (0.22 log units), on the high side, and the stated range covers the measured number.
By their numbers in this assay, from the lowest: compound 4; then compounds 3 and 1 (each within the scatter of the next); then compound 2.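

At the aromatic carbon of the shared core, ((3-bromophenyl)sulfanyl)methyl in place of (cyclohexylmethyl)sulfanyl gives a 4.3-fold lower number from compound 1 to compound 4 (0.63 log units; beyond the scatter) in this assay. Among the compounds shown here, all earlier compounds keep sulfur bound directly to that carbon, so this is the first sign that the position tolerates a saturated carbon there, with the sulfur further out and a bromine-bearing aromatic ring at the end. No measurement explains this gain.

On these data alone, the ring, the bromine and the sulfur position change together, so their separate contributions remain open. Also open, as far as these compounds go, is how chlorine, a methoxy group or an amine would compare with bromine on that ring.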